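Replacing 4-cyanophenyl with 3-methylpyridin-4-yl in compound 3

A few compounds are considered here, and "the series" means these few. Any claim that something is new, unique, unknown or untested is made for them only; others in the source may bear on it.

Of the compounds shown here, three have been measured in a physicochemical assay for lipophilicity, using the shake flask method, in phosphate buffer, measured as octanol-water partition, at pH 7.4; a lower number here means a more polar compound, a higher number a more lipophilic compound. In this set, compound 1 `CC(C)(C)OC(=O)N1CCN(c2ncc(-c3ccc(OCC#N)cc3)cn2)CC1` gives 4.2 and compound 2 `CC(C)(C)OC(=O)N1C[C@@H]2C[C@H]1CN2c1ncc(OCc2ccc(S(C)(=O)=O)cc2)cn1` gives 2.8. Compound 3 `C[C@@H]1CN(C(=O)OC(C)(C)C)CCN1c1ncc(OCc2ccc(C#N)cc2)cn1` carries no number of its own, only the limit > 3.6.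

Compound 4 `Cc1cnccc1COc1cnc(N2CCN(C(=O)OC(C)(C)C)C[C@H]2C)nc1` has not yet been measured, and it differs from compound 3 in one place: 3-methylpyridin-4-yl in place of 4-cyanophenyl on a saturated chain carbon bound to an oxygen on an aromatic ring. Here 3-methylpyridin-4-yl stands in place of 4-cyanophenyl on a saturated chain carbon bound to an oxygen on an aromatic ring. Among the measured compounds shown here, no pair of measured compounds differs in only one place, so this exchange has no direct precedent in the data. A modest fall in this assay is nevertheless expected, and the estimated change is a number at least 0.20 log units lower from compound 3 to compound 4 (that floor lies within the scatter). The starting point of that step is only a limit, so its size remains loosely fixed. The expectation stays inside the span marked by compound 2 at 2.8 and compound 1 at 4.2. For compound 4, the expected value is 3.4, within an estimated range of 2.9 to 3.9.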

Compound 4, distribution coefficient: 3.8
Estimate against measurement, compound 4: 0.40 log units below; low and high end bracket the measured number.
By their numbers in this assay, from the lowest: compound 2; then compound 4; then compound 1.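

No step can be read from compound 3 to compound 4 in this assay, because compound 3 carries only a limit, not a number: the limit of > 3.6 in this assay, at which 1 of the 4 values shown sits.

The compounds shown leave open both the size and the direction of the change when 3-methylpyridin-4-yl stands in place of 4-cyanophenyl.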